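Amino in place of dimethylamino: working notes

The source may hold more compounds than are shown below. What is called first, only, known or untested is meant among the compounds shown, and "the series" means these compounds.

Measured so far in a functional assay on HCT-116 cells (Homo sapiens) for antiproliferative activity, read by MTT assay, with a stated time of 48 h (a lower number here means a stronger inhibitor, a higher number a weaker inhibitor), are these values.
Compound 1 `CCCCCC(CCO)n1cnc2c(N)ncnc21` gives > 50000 nM.
Compound 2 `CCCCCCCCC(CCO)n1cnc2c(OC)ncnc21` gives 12800 nM.
Compound 3 `CCCCCCCCC(CCO)n1cnc2c(N(C)C)ncnc21` gives 19800 nM.

The entry of compound 1 is a limit and not a number (the limit of > 50000 nM in this assay, at which 1 of the 3 values shown sits).

Within the data shown here, compound 3 has 19800 nM as its value and sits within the scatter of compound 2, the only other number. Compound 4 `CCCCCCCCC(CCO)n1cnc2c(N)ncnc21` is not yet measured and differs from compound 3 in one group, with amino in place of dimethylamino on an aromatic carbon.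

Among the measured compounds shown here, the one measured step at this carbon is a 1.5-fold higher number from compound 2 to compound 3 (0.19 log units; within the scatter) with dimethylamino in place of methoxy, so changing that group has not yet moved the number beyond the scatter. Compound 1 also carries amino there but differs elsewhere in its structure. No step beyond the scatter is therefore expected in this assay and no firm direction. The estimated change is a 1.3-fold lower number from compound 3 to compound 4 (0.12 log units; within the scatter) and stays small. Compound 4 is expected at 15000 nM with an estimated range of 6000 nM to 40000 nM in this assay's terms.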

Compound 4, half-maximal inhibitory concentration: 11600 nM
For compound 4 the middle estimate is 1.3-fold (0.11 log units) above the measured one; low and high end bracket the measured number.
By their numbers in this assay, from the lowest: compounds 4, 2 and 3 (each within the scatter of the next). At a limit, above all of these: compound 1.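

In this assay, amino, methoxy and dimethylamino on this aromatic carbon are not separated: a 1.7-fold lower number from compound 3 to compound 4 (0.23 log units; within the scatter), and a 1.1-fold lower number from compound 2 to compound 4 (0.04 log units; within the scatter). The hydrogen-bond donor that enters with amino in place of dimethylamino therefore comes with no step beyond the scatter. The only step beyond the scatter lies on the chain, with propyl in place of hydrogen, an at least 4.3-fold lower number from compound 1 to compound 4 (0.63 log units; beyond the scatter), and its size rests on a limit, not a number: the limit of > 50000 nM in this assay, at which 1 of the 4 values shown sits.

Going by these compounds, it remains open whether a carboxylic acid or a benzylamino group on this aromatic carbon would move the number beyond the scatter. On these data alone, it also remains open whether a chain longer than that of compound 4 would lower the number further or whether the trend along the chain stops there.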